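A few compounds are considered here, and "the series" means these few. Any claim that something is new, unique, unknown or untested is made for them only; others in the source may bear on it.

Notes on the series in a functional assay on MX1 cells (Homo sapiens) for inhibition, read by MTT assay, with a stated time of 120 h; on this read-out higher numbers stand for weaker inhibition and lower numbers for stronger inhibition.

Compound 1 `CNC(=O)/C(C)=C/c1ccc(NC(=O)Nc2ccc(Cl)c(C(F)(F)F)c2)cc1` returns only a limit of the assay, > 50000 nM. Compound 3 `CNC(=O)/C=C(\C)c1ccc(NC(=O)Nc2ccc(Cl)c(C(F)(F)F)c2)cc1` likewise gives only a limit, > 50000 nM. Compound 2 `C/C(=C\C(=O)N1CC(C)OC(C)C1)c1ccc(NC(=O)Nc2ccc(Cl)c(C(F)(F)F)c2)cc1` also stops at a limit, > 50000 nM. All three sit at the limit of > 50000 nM in this assay, at which 3 of the 3 values shown sit, so no ordering among them is readable.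

The cores of compound 1 and compound 3 differ as 2-(methylcarbamoyl)prop-1-en-1-yl in place of 1-methyl-2-(methylcarbamoyl)ethenyl on an aromatic carbon; the step that the two limits leave unreadable from compound 1 to compound 3 is unreadable. From compound 3 to compound 2 the change is 2,6-dimethylmorpholin-4-yl in place of methylamino on a carbonyl carbon, and the step that the two limits leave unreadable from compound 3 to compound 2 is likewise unreadable.

Compound 4 `C/C(=C\c1ccc(NC(=O)Nc2ccc(Cl)c(C(F)(F)F)c2)cc1)C(=O)N1CC(C)OC(C)C1` carries the same kind of change on the core of compound 1, (2,6-dimethylmorpholin-4-yl in place of methylamino on a carbonyl carbon), with the place described in identical words.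

Since the matching step that the two limits leave unreadable from compound 3 to compound 2 could not be read and every value stands at the limit of > 50000 nM in this assay, at which 3 of the 3 values shown sit, the step from compound 1 to compound 4 is expected to be a step that the limit leaves unreadable from compound 1 to compound 4, meaning compound 4 is estimated at 70000 nM, most likely again only a limit, with a range of 20000 nM to 250000 nM.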

Compound 4, half-maximal inhibitory concentration: > 50000 nM
Compound 4 was reported as a limit (the forecaster's own chance of this, stated with the estimate: 85%); the middle value does not contradict the limit.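

Compound 1 and compound 4 both stop at a limit, so no new step can be read between them: the limit of > 50000 nM in this assay, at which 4 of the 4 values shown sit.

The compounds shown leave open how far either change on the shared core alters inhibition.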